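The source may hold more compounds than are shown below. What is called first, only, known or untested is meant among the compounds shown, and "the series" means these compounds.

Among the measured compounds shown here, in an ADME assay on PC-3 cells (Homo sapiens) for cytotoxicity, read by WST assay, tested at 100 uM (on this read-out lower numbers stand for less inhibition and higher numbers for more inhibition at the one concentration tested (going by the name of the read-out)), compound 2 `C=Cc1cccc(C(=O)N2CCCC(C(=O)Nc3ccc(Cl)cc3)C2)c1` gives 0%, and compound 1 `CC(=O)Nc1cccc(C(=O)N2CCCC(C(=O)Nc3ccc(Cl)cc3)C2)c1` gives 4%, the two numbers lying within the scatter of each other; the one step recorded, a number 4 percentage points lower from compound 1 to compound 2 (within the scatter), is likewise within the scatter. Compound 3 `COCc1cccc(C(=O)N2CCCC(C(=O)Nc3ccc(Cl)cc3)C2)c1` carries methoxymethyl in place of vinyl on an aromatic carbon. For the measured compounds named here, no measured step covers methoxymethyl in place of vinyl on an aromatic carbon, so the expectation rests only on compound 1 and compound 2 both sitting near zero in this assay. The step of a number 3 percentage points higher from compound 2 to compound 3 (within the scatter) is therefore expected to stay within the scatter, with no direction beyond it. Compound 3 is estimated at 3%, with a range from -8% to 15%.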

Compound 3, a percentage reported as inhibition, at one concentration (the size of the read-out at that concentration, not a potency): 0%
For compound 3 the middle estimate is 3 percentage points above the measured one, and the stated range covers the measured number.
By their numbers in this assay, from the lowest: compounds 2, 3 and 1 (each within the scatter of the next).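

In this assay, the change from 3-vinylphenyl to 3-(methoxymethyl)phenyl gives no change at the digits printed from compound 2 to compound 3 (within the scatter) and the replacement of acetamido gives a number 4 percentage points lower from compound 1 to compound 3 (within the scatter) at the same place on the aromatic ring. Methoxymethyl, which brings a hydrogen-bond acceptor where vinyl has none, thus joins vinyl and acetamido in a set of three groups that cannot be told apart at this position. No available evidence bears on why these readings coincide. Still open, as far as these compounds go, is whether an amine, a carboxylic acid or a longer chain at this position would separate from these three beyond the scatter.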